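The source may report more compounds than this note shows. Statements on the series, on what has been measured and on what is new or still open speak of the compounds shown alone.

Compound 1, with the structure `O=c1c(-c2ccccc2)coc2cc(OC/C(=N/O)c3ccccc3)ccc12`, gives in a functional assay on SK-HEP1 cells (Homo sapiens) for antiproliferative activity (on this read-out lower numbers stand for stronger inhibition of growth and higher numbers for weaker inhibition of growth), a value of 6400000 nM. Compound 2, with the structure `O=c1c(-c2ccccc2)coc2cc(OC/C(=N/O)c3ccc(F)cc3)ccc12`, differs from compound 1 by fluoro in place of hydrogen on an aromatic carbon, and in this assay compound 2 gives 6610000 nM. That change made a 1.0-fold higher number from compound 1 to compound 2 (0.01 log units; within the scatter).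

Compound 3, with the structure `CO/N=C(/COc1c(-c2ccccc2)oc2ccccc2c1=O)c1ccccc1`, carries a different core; how the core of compound 3 differs from that of compound 1 is not broken down here. In this assay compound 3 gives 7110000 nM, and its value lies within the scatter of those of compound 1 and compound 2.

Compound 4, with the structure `CO/N=C(/COc1c(-c2ccccc2)oc2ccccc2c1=O)c1ccc(F)cc1`, has not yet been measured. It differs from compound 3 by fluoro in place of hydrogen on an aromatic carbon, the same change that separates compound 2 from compound 1. Because that change gave a 1.0-fold higher number from compound 1 to compound 2 (0.01 log units; within the scatter) on the core of compound 1, the step from compound 3 to compound 4 is expected to be a 1.0-fold higher number from compound 3 to compound 4 (0.01 log units; within the scatter). On that basis compound 4 is estimated to give 7300000 nM in this assay, most likely between 3600000 nM and 14500000 nM.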

Compound 4, concentration for 50% growth inhibition: 13000000 nM
For compound 4 the middle estimate is 1.8-fold (0.25 log units) below the measured one; measured number inside the range.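

On the core of compound 3, the change from phenyl to 4-fluorophenyl in this assay amounts to a 1.8-fold higher number from compound 3 to compound 4 (0.26 log units; within the scatter). Set beside the same change on the core of compound 1, the two steps do not differ: the same change on two cores in this assay, a 1.0-fold higher number (0.01 log units; within the scatter) from compound 1 to compound 2 and a 1.8-fold higher number (0.26 log units; within the scatter) from compound 3 to compound 4, 1.8-fold (0.25 log units) apart, within the scatter of two such steps. In these two pairs, then, the fluoro group carries from one core to the other with a step inside the scatter on each, but two pairs cannot show that it would do so on further cores or in another read-out, and they say nothing about why the numbers stand as they do.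

The compounds shown hold only hydrogen or fluoro at this place, so it remains open whether chloro, methoxy, an amine or a carboxylic acid there would also transfer between the two cores. Going by these compounds, it is also open how a longer chain in place of the methyl group of compound 3 and compound 4 would read in this assay.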